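A few compounds are considered here, and "the series" means these few. Any claim that something is new, unique, unknown or untested is made for them only; others in the source may bear on it.

Measured in a functional assay on MKN-45 cells (Homo sapiens) for cytotoxicity, read by MTT assay, with a stated time of 72 h; a lower number here means a stronger inhibitor, a higher number a weaker inhibitor:

- compound 1, `COc1cccc(-c2cc(C(=O)Nc3ccc(Oc4ccnc5cc(OCCCN6CCCCC6)c(OC)cc45)c(F)c3)c3ccccc3n2)c1`: 360 nM
- compound 2, `COc1cc2c(Oc3ccc(NC(=O)c4cc(-c5cccc(Cl)c5)nc5ccccc45)cc3F)ccnc2cc1OCCCN1CCC(C)CC1`: 30 nM
- compound 3, `COc1cc2c(Oc3ccc(NC(=O)c4cc(-c5ccc(C)cc5)nc5ccc(F)cc45)cc3F)ccnc2cc1OCCCN1CCCCC1`: 170 nM

Compound 3 stands second highest of the three numbers in this assay. Its nearest neighbour is compound 1, whose number is higher by a gap beyond the usual scatter; compound 2 lies furthest away, with a lower number, again beyond the scatter. Among the measured compounds shown here, the three compounds differ from each other in more than one place, so no single-change step among them can be read off.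

Compound 4, `COc1cc2c(Oc3ccc(NC(=O)c4cc(-c5ccc(Cl)cc5Cl)nc5ccc(F)cc45)cc3F)ccnc2cc1OCCCN1CCCCC1`, is not yet measured. It differs from compound 3 in one place: 2,4-dichlorophenyl in place of 4-methylphenyl on an aromatic carbon. The nearest point of comparison is compound 2, which carries a chlorine-bearing phenyl ring and gives the lowest number of the set, though it also differs from compound 3 elsewhere. On that basis a modest decrease in number is expected from compound 3 to compound 4 in this assay, estimated at a 1.7-fold lower number from compound 3 to compound 4 (0.23 log units; within the scatter), which may yet fall within the scatter. Compound 4 is expected to give about 100 nM, in the range 30 nM to 400 nM.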

Compound 4, half-maximal inhibitory concentration: 250 nM
Compound 4: middle estimate off by 2.5-fold (0.40 log units), on the low side, and the stated range covers the measured number.
By their numbers in this assay, from the lowest: compound 2; then compounds 3, 4 and 1 (each within the scatter of the next, the first and the last beyond it).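

Among the compounds shown here, the step at this position, on the aromatic carbon next to the ring nitrogen, is the only single change that can be read so far. In this assay, 2,4-dichlorophenyl in place of 4-methylphenyl gives a small shift (a 1.5-fold higher number from compound 3 to compound 4 (0.17 log units; within the scatter)), so the two rings are not told apart at this position on the core of compound 3. Adding two chlorines and removing the methyl therefore brings no readable gain or loss here, and no measurement at hand bears on why the step is this small.

Going by these compounds, it remains open whether a 4-chlorophenyl or 2-chlorophenyl ring, or a saturated amine such as morpholine, would separate from 4-methylphenyl at this position. Also open, on these data alone, is whether the same exchange would stay this small on the core of compound 2.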